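The compounds below may be only part of what the source reports. "The series", "measured", "known", "first", "only" and "open" are said of these compounds alone.

Two compounds of this series share the same core and have been measured in a functional assay on HeLa cells (Homo sapiens) for antiproliferative activity, read by CCK-8 assay, with a stated time of 72 h, tested at 8 uM; on this read-out lower numbers stand for a weaker effect and higher numbers for a stronger effect at the one concentration tested. Compound 1, with the structure `Nc1ccccc1NC(=O)c1ccc(CSC(=S)N2CCN(c3ccc(Cl)cc3)CC2)cc1`, gives 44.8% and stands lowest of the two numbers. Compound 2, with the structure `CC1CCN(C(=S)SCc2ccc(C(=O)Nc3ccccc3N)cc2)CC1`, gives 72.5%, a number that lies beyond the scatter above that of compound 1; the two structures differ in more than one place, so the gap cannot be tied to any single change.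

Compound 3, with the structure `Cc1ccc(N2CCN(C(=S)SCc3ccc(C(=O)Nc4ccccc4N)cc3)CC2)cc1`, has not yet been measured. It differs from compound 1 in one place only: methyl in place of chloro on an aromatic carbon. The rest of the molecule is kept as it is.

Among the compounds with values here, no measured pair in this set isolates a change of that kind, so there is nothing to copy a step from. A methyl group standing in for a chloro group at the same aromatic carbon is a small exchange, and the expected step in this assay is correspondingly small, within the scatter in either direction.

Compound 3 is therefore estimated to give 48%, within a range from 30% to 68%, meaning an expected step of a number 3.2 percentage points higher from compound 1 to compound 3 (within the scatter).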

Compound 3, a percentage reported as inhibition, at one concentration (the size of the read-out at that concentration, not a potency): 24%
Beside the measured number, compound 3's estimate is 24 percentage points above it; measured number below the stated range.
By their numbers in this assay, from the lowest: compound 3; then compound 1; then compound 2.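

In this assay, within the data shown here, putting methyl in place of chloro on the aromatic carbon para to a large group gives a number 20.8 percentage points lower from compound 1 to compound 3 (beyond the scatter), and this is the first change in the set that can be read on its own. It shows that this position is not indifferent: replacing one heavy atom with one other heavy atom is enough to move the read-out past the usual scatter, even though the counts of rings, hydrogen-bond donors and acceptors and the net charge all stay the same. Nothing at hand explains why the 4-chlorophenyl and 4-methylphenyl compounds differ, so the step stands as an observation only.

Among the compounds shown, only chloro and methyl sit at this position, so it remains open whether a methoxy group, a fluoro group or an amine on the same carbon would land near compound 1, near compound 3 or somewhere else. A reading at a single concentration also leaves open how compound 1 and compound 3 would compare across a range of concentrations.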